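A few compounds are considered here, and "the series" means these few. Any claim that something is new, unique, unknown or untested is made for them only; others in the source may bear on it.

Compound 3 `O=C(N/N=C/N1CCN(c2cc3c(cc2F)c(=O)c(C(=O)O)cn3C2CC2)CC1)c1cccc(C(F)(F)F)c1` is the measured neighbour of the new compound. In an ADME assay on PBMC cells (Homo sapiens) for cytotoxicity, read by MTT assay (on this read-out lower numbers stand for stronger inhibition and higher numbers for weaker inhibition), compound 3 gives > 322000 nM, which is a limit of the assay rather than a number. Compound 2 `O=C(N/N=C/N1CCN(c2cc3c(cc2F)c(=O)c(C(=O)O)cn3C2CC2)CC1)c1ccc(C(F)(F)F)cc1` gives 347000 nM in this assay, and compound 1 `O=C(N/N=C/Nc1ccc(C(=O)O)c(O)c1)c1cccc(C(F)(F)F)c1` gives "not determined" (no result reported). The step that the limit leaves unreadable from compound 2 to compound 3 cannot be sized because of the limit of > 322000 nM in this assay, at which 1 of the 3 values shown sits. Compound 4 `O=C(N/N=C/N1CCN(c2cc3c(cc2F)c(=O)c(C(=O)O)cn3C2CC2)CC1)c1cccc(F)c1` differs from compound 3 by fluoro in place of trifluoromethyl on an aromatic carbon of a six-membered aromatic ring of carbon only, meta to a large group. No measured step bears on this change, and the one step shown is unreadable. Compound 4 is therefore expected to stay close to compound 3, a step that the limit leaves unreadable from compound 3 to compound 4 no larger than the scatter. Compound 4 is estimated at 350000 nM, between 150000 nM and 800000 nM.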

Compound 4, half-maximal inhibitory concentration: > 305000 nM
Compound 4: no number, only a limit; the forecaster's own chance of this, stated with the estimate: 60%; the middle value lies beyond the limit too.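

Among the compounds shown here, compound 3 and compound 4 carry only limits in this assay, so no step among compound 2, compound 3 and compound 4 can be read. Going by these compounds, whether fluoro in place of trifluoromethyl shifts this read-out at all stays open.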